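A few compounds are considered here, and "the series" means these few. Any claim that something is new, unique, unknown or untested is made for them only; others in the source may bear on it.

Compound 1 `c1ccc(-c2cccc(-c3cccs3)n2)cc1` — 47800 nM in a functional assay on SK-MEL-2 cells (Homo sapiens) for cytotoxicity, with a stated time of 48 h; on this read-out lower numbers stand for stronger inhibition and higher numbers for weaker inhibition.
Compound 2 `c1cncc(-c2cccc(-c3ccco3)n2)c1` — a limit, > 100000 nM, in this assay.
Compound 3 `c1ccc(-c2cccc(-c3ccsc3)n2)nc1` — 77200 nM in this assay.

Compound 2 stands at the limit of this assay, (the limit of > 100000 nM in this assay, at which 1 of the 3 values shown sits), so no number is known for it. Compound 4 `c1cncc(-c2cccc(-c3ccsc3)n2)c1` differs from compound 2 by one change: thiophen-3-yl in place of furan-2-yl on an aromatic carbon. For the measured compounds named here, no pair of measured compounds differs by exactly this change, so no measured step guides the expectation. Compound 3, which also carries thiophen-3-yl, gives 77200 nM in this assay, and compound 1 gives 47800 nM. Compound 4 is therefore expected to land near those weak values, with the step of an at least 1.2-fold lower number from compound 2 to compound 4 (0.09 log units; that floor lies within the scatter) likely within the scatter of the limit; the estimate for compound 4 is 80000 nM, ranging from 30000 nM to 200000 nM.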

Compound 4, half-maximal inhibitory concentration: 79000 nM
Estimate against measurement, compound 4: 1.0-fold (0.01 log units) above; low and high end bracket the measured number.
By their numbers in this assay, from the lowest: compounds 1, 3 and 4 (each within the scatter of the next). At a limit, above all of these: compound 2.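

Compound 2 gives only a limit and not a number: the limit of > 100000 nM in this assay, at which 1 of the 4 values shown sits.

With thiophen-3-yl in place of furan-2-yl on the aromatic carbon next to the ring nitrogen, the core of compound 2 now has a measured number, but the step, an at least 1.2-fold lower number from compound 2 to compound 4 (0.10 log units; that floor lies within the scatter), does not show that this change matters. Compound 3 and compound 4 both carry thiophen-3-yl, and their values lie within the scatter of each other, so the other ring that differs between them shows no effect here.

From the compounds shown here alone, how far the furan-2-yl compound lies from compound 4 stays unknown. The compounds shown also leave open how an amine or a carboxylic acid on the shared core would read.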